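The compounds below may be only part of what the source reports. "The series", "measured", "known", "first", "only" and "open" are said of these compounds alone.

Measured so far:
compound 1 `CCO/C=N/c1c(C#N)ncn1Cc1ccccc1`: 1.9%
compound 2 `Cc1ccc(-c2ncc3[nH]c(=O)n(Cc4ccccc4)c3n2)cc1`: 71.1%

Two compounds have been run in an assay on HeLa cells for displacement of a labelled ligand from adenosine receptor A3 (Homo sapiens), read by scintillation counting, with a stated time of 180 min, tested at 10 uM; a lower number here means less inhibition, a higher number more inhibition at the concentration tested (going by the name of the read-out). Compound 1 gives 1.9%, the lower of the two numbers; compound 2 gives 71.1%, a gap beyond the usual scatter. Compound 3 `CCO/C(C)=N/c1c(C#N)ncn1Cc1ccccc1` has not yet been measured. It differs from compound 1 in one place: a group of 6 heavy atoms (4 carbon, 1 nitrogen, 1 oxygen; no ring) in place of a group of 5 heavy atoms (3 carbon, 1 nitrogen, 1 oxygen; no ring), on an aromatic carbon. Going by the values given here, with no measured pair showing this change, a step from compound 1 to compound 3 that stays within the scatter is expected, as a number 3.1 percentage points higher from compound 1 to compound 3 (within the scatter). Compound 3 is therefore estimated at 5%, within -5% to 20%.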

Compound 3, a percentage reported as inhibition, at one concentration (the size of the read-out at that concentration, not a potency): 28%
For compound 3 the middle estimate is 23 percentage points below the measured one, outside the stated range (above it).
By their numbers in this assay, from the lowest: compound 1; then compound 3; then compound 2.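

At the aromatic carbon next to the ring nitrogen, the reading in this assay proves sensitive to a small change: a number 26.1 percentage points higher from compound 1 to compound 3 (beyond the scatter) comes with a group of 6 heavy atoms in place of a group of 5 heavy atoms. Both groups have the same counts of hydrogen-bond donors and acceptors, and neither carries a net charge, so these counts do not separate them. Nothing available explains the step. As far as these compounds go, whether an amine or a longer chain on this carbon would raise the number further remains open.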